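The source may report more compounds than this note shows. Statements on the series, on what has been measured and on what is new or still open speak of the compounds shown alone.

Compound 1 `O=C1C=C(Nc2ccc(I)cc2)C(=O)c2c1nc1n2[C@H]2OC[C@@H](O)[C@H]2OC1` is the reference point here. In a functional assay on MCF7 cells (Homo sapiens) for inhibition, read by sulforhodamine B assay (a lower number here means a stronger inhibitor, a higher number a weaker inhibitor), compound 1 gives 2230 nM. Compound 2 `COc1cccc(NC2=CC(=O)c3c(nc4n3[C@H]3OC[C@@H](O)[C@H]3OC4)C2=O)c1` carries a (3-methoxyphenyl)amino group in place of the (4-iodophenyl)amino group, and in this assay compound 2 gives 3830 nM; the two numbers lie within the usual scatter of each other, so no order between compound 1 and compound 2 can be read from them. Compound 3 `O=C1C(N2CCCCC2)=CC(=O)c2c1nc1n2[C@H]2OC[C@@H](O)[C@H]2OC1` replaces the anilino group altogether with piperidin-1-yl. In this assay compound 3 reaches only a limit, > 8000 nM, and that is the limit noted as the limit of > 8000 nM in this assay, at which 1 of the 3 values shown sits. Among the compounds with values here, the one measured step, an at least 2.0-fold higher number from compound 2 to compound 3 (0.31 log units; beyond the scatter), is at least modest and concerns the loss of the arylamino group rather than a change on the aryl ring.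

Compound 4 `CCc1ccc(NC2=CC(=O)c3nc4n(c3C2=O)[C@H]2OC[C@@H](O)[C@H]2OC4)cc1` differs from compound 1 by ethyl in place of iodo on an aromatic carbon. Within the data shown here, no measured step speaks to a change on the aryl ring itself; the nearest evidence is that compound 1 and compound 2, with different substituents on that ring, sit within the scatter of one another. Compound 4 is therefore expected to stay close to compound 1, and the expected step of a 1.1-fold higher number from compound 1 to compound 4 (0.05 log units; within the scatter) is none beyond the scatter. The estimate for compound 4 in this assay is 2500 nM, with a range from 1100 nM to 6000 nM.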

Compound 4, half-maximal inhibitory concentration: 960 nM
Compound 4: middle estimate off by 2.6-fold (0.42 log units), on the high side, outside the stated range (below it).
By their numbers in this assay, from the lowest: compound 4; then compounds 1 and 2 (each within the scatter of the next). At a limit, above all of these: compound 3.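

In this assay, within the data shown here, the only earlier step beyond the scatter, an at least 2.0-fold higher number from compound 2 to compound 3 (0.31 log units; beyond the scatter), removed the arylamino group altogether, so it said nothing about the aryl ring itself. The new change keeps that group and alters only the substituent on the ring, going from (4-iodophenyl)amino to (4-ethylphenyl)amino, and it gives a 2.3-fold lower number from compound 1 to compound 4 (0.37 log units; beyond the scatter), which shows that this position on the aromatic ring can move the number by itself, though modestly and in this one pair only. Nothing measured here bears on why ethyl and iodo differ at this place.

The compounds shown leave open whether the trend continues with a longer chain such as propyl or butyl in the same position, and whether the lower number depends on ethyl in particular or would also be reached with methyl or chloro. They also leave open how a hydroxyl, an amine or a carboxylic acid at this place would read in this assay, since the substituents shown on this ring are limited to iodo and ethyl at this position.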